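This account rests on a few compounds, and the source may have more. Where it says the series, first, only, none or still open, it means among the compounds named here.

The series shares one core and varies the group on the six-membered aromatic ring with one nitrogen. Compound 1 `CCCN(CCC)c1cc(C)nc2c(-c3ncc([N+](=O)[O-])cc3C)c(C)nn12` carries a nitro group there and gives 9.1 nM in an assay on isolated protein for binding affinity to corticotropin-releasing factor receptor 1 (Homo sapiens); on this read-out lower numbers stand for stronger inhibition and higher numbers for weaker inhibition. Compound 2 `CCCN(CCC)c1cc(C)nc2c(-c3ncc(N)cc3C)c(C)nn12` carries an amino group and gives 85 nM; compound 3 `CCCN(CCC)c1cc(C)nc2c(-c3ncc(NC)cc3C)c(C)nn12` carries a methylamino group and gives 40 nM. Compound 3 thus stands second highest of the three numbers: a 4.4-fold higher number from compound 1 to compound 3 (0.64 log units; beyond the scatter), while a 2.1-fold lower number from compound 2 to compound 3 (0.33 log units; beyond the scatter). Compound 4 `CCCN(CCC)c1cc(C)nc2c(-c3ncc(N(CC)CC)cc3C)c(C)nn12` differs from compound 3 as follows: diethylamino in place of methylamino on an aromatic carbon. Among the compounds with values here, the only step that bears on it is the one from compound 2 to compound 3, where a methyl on the nitrogen gave a modest lowering of the number; the step from compound 1 to compound 2 concerns a different exchange. Extending the alkyl on the nitrogen further is expected to bring, at most, another modest lowering or none beyond the scatter. Compound 4 is therefore estimated at 30 nM, with an expected range from 10 nM to 90 nM. This estimate corresponds to an expected step of a 1.3-fold lower number from compound 3 to compound 4 (0.12 log units; within the scatter).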

Compound 4, inhibition constant: 13 nM
The estimate for compound 4 lay 2.3-fold (0.36 log units) above the measured number; the range from low to high includes it.
By their numbers in this assay, from the lowest: compounds 1 and 4 (each within the scatter of the next); then compound 3; then compound 2.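

At this position, diethylamino goes beyond what the single methyl on the nitrogen gave: in this assay there is a 3.1-fold lower number from compound 3 to compound 4 (0.49 log units; beyond the scatter) and, against the free amino group, a 6.5-fold lower number from compound 2 to compound 4 (0.82 log units; beyond the scatter). The nitro level is also not unique to nitro among the groups shown, as diethylamino gives a 1.4-fold higher number from compound 1 to compound 4 (0.15 log units; within the scatter). The change from methylamino to diethylamino both lengthens the alkyl groups and removes the hydrogen on the nitrogen, and no measurement at hand accounts for the gain.

The compounds shown do not separate these two changes; dimethylamino or ethylamino would bear on that. From the compounds shown here alone, whether a longer chain on the nitrogen, as in dipropylamino, or a ring amine such as morpholine holds the level of compound 4 also remains open.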